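A few compounds are considered here, and "the series" means these few. Any claim that something is new, unique, unknown or untested is made for them only; others in the source may bear on it.

Values in an ADME assay on brain (Rattus norvegicus) for protein binding; on this read-out higher numbers stand for a larger free fraction and lower numbers for a smaller free fraction:
- Compound 1 `Cc1cccc(-c2ccc(NC[C@H]3CC[C@]4(CC3)CN(c3cccnn3)C(=O)O4)nc2)n1`: 0.056
- Compound 2 `O=C1O[C@]2(CC[C@H](CNc3ccc(-c4cc(F)cc(F)c4)nn3)CC2)CN1c1cccnn1`: 0.016

Of these two, compound 2 has the lower number, and the gap up to compound 1 is larger than the usual scatter of repeated measurements. So little of compound 2 is free in this assay.

Compound 3 `Cc1ccccc1-c1ccc(NC[C@H]2CC[C@]3(CC2)CN(c2cccnn2)C(=O)O3)nn1` carries 2-methylphenyl in place of 3,5-difluorophenyl on an aromatic carbon. For the measured compounds named here, no two measured compounds differ in one place only, so no measured step shows what such a swap does. Going by the values given here, the two values show only that compound 1, at 0.056, sits higher than compound 2. A small rise, not clearly beyond the scatter, is therefore expected. The estimated change is a 1.5-fold higher number from compound 2 to compound 3 (0.18 log units; within the scatter). For compound 3 the expected value is 0.024, with an estimated range from 0.011 to 0.05.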

Compound 3, unbound fraction: 0.051
Beside the measured number, compound 3's estimate is 2.1-fold (0.33 log units) below it; measured number outside the range, above it.
By their numbers in this assay, from the lowest: compound 2; then compounds 3 and 1 (each within the scatter of the next).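

In this assay, 2-methylphenyl in place of 3,5-difluorophenyl gives a 3.2-fold higher number from compound 2 to compound 3 (0.50 log units; beyond the scatter), and this is the first step shown in which only one place differs. It shows that the group on this aromatic carbon, in the six-membered aromatic ring with 2 nitrogen, can by itself shift the free fraction by more than the scatter while the rest of the molecule stays the same. Nothing available explains the rise, so it stands as an observation only.

This single swap removes the two fluorines and adds the methyl together, so the compounds shown cannot separate those two changes. Also open, from the compounds shown here alone, is how plain phenyl, or a phenyl ring carrying an amine or a carboxylic acid, would read in this assay.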